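Amide Substituent Change on the Shared Core

The source may report more compounds than this note shows. Statements on the series, on what has been measured and on what is new or still open speak of the compounds shown alone.

Measured compounds:
Compound 1 `CCN(CC)CCNC(=O)c1ccc(C(CC)(CC)c2ccc(OCC(=O)C(C)(C)C)c(C)c2)n1CC`: 91 nM
Compound 2 `CCn1c(C(=O)NCC(OC)OC)ccc1C(CC)(CC)c1ccc(OCC(=O)C(C)(C)C)c(C)c1`: 130 nM

Within the data shown here, in an assay on HL-60 cells for agonist activity at vitamin D3 receptor (Homo sapiens), read by microscopy, with a stated time of 96 h (on this read-out higher numbers stand for an effect only at larger amounts of compound and lower numbers for an effect already at smaller amounts), compound 1 gives 91 nM and compound 2 gives 130 nM; the one measured step, a 1.4-fold higher number from compound 1 to compound 2 (0.15 log units; within the scatter), lies within the scatter. Compound 3 `CCn1c(C(=O)N(C)CCC#N)ccc1C(CC)(CC)c1ccc(OCC(=O)C(C)(C)C)c(C)c1` carries (2-cyanoethyl)(methyl)amino in place of (2,2-dimethoxyethyl)amino on a carbonyl carbon. Among the measured compounds shown here, only that step bears on it, and it changed the amide substituent without moving the number. The expected step of a 1.2-fold higher number from compound 2 to compound 3 (0.06 log units; within the scatter) is therefore small. For compound 3 the estimate is 150 nM, with a range from 60 nM to 400 nM.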

Compound 3, half-maximal effective concentration: 9800 nM
Compound 3: middle estimate off by 65-fold (1.82 log units), on the low side; measured number outside the range, above it.
By their numbers in this assay, from the lowest: compounds 1 and 2 (each within the scatter of the next); then compound 3.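

In this assay, this position is not indifferent to the amide substituent: there is a 75-fold higher number from compound 2 to compound 3 (1.88 log units; beyond the scatter), and a 110-fold higher number from compound 1 to compound 3 (2.03 log units; beyond the scatter), so the earlier flat step extends only to the two substituents that keep the amide hydrogen. Compound 3 alone lacks that hydrogen, and it alone carries a nitrile. No measurement at hand explains this rise.

The compounds shown leave open whether the rise goes with the nitrile or with the methyl on the amide nitrogen. A (2-cyanoethyl)amino group, which keeps the amide hydrogen, would separate the two.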